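The source may report more compounds than this note shows. Statements on the series, on what has been measured and on what is new or still open speak of the compounds shown alone.

For the measured compounds named here, in an in vitro ADME assay on microsomes from liver (Rattus norvegicus) for metabolic stability (on this read-out higher numbers stand for fast clearance and lower numbers for slow clearance), compound 1 `Clc1cccc(-c2ccc(N3CCCCC3)nn2)c1Cl` gives 35 mL.min-1.g-1, while compound 2 `C[C@@H]1CC[C@H](C)N1c1ccc(-c2cccc(Cl)c2Cl)nn1` gives 9.7 mL.min-1.g-1, the lower of the two numbers measured so far. Going by the values given here, the only measured step is a 3.6-fold lower number from compound 1 to compound 2 (0.56 log units; beyond the scatter). There, 2,5-dimethylpyrrolidin-1-yl takes the place of piperidin-1-yl on an aromatic carbon, a modest change that lies beyond the usual scatter.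

Compound 3 `C[C@@H]1C=C[C@H](C)N1c1ccc(-c2cccc(Cl)c2Cl)nn1` keeps the shared core of compound 2 and alters the same group: a group of 7 heavy atoms (6 carbon, 1 nitrogen; one five-membered non-aromatic ring with 1 hetero atom) in place of a group of 7 heavy atoms (6 carbon, 1 nitrogen; one five-membered non-aromatic ring with 1 hetero atom), on an aromatic carbon. The entering group has a double bond outside aromatic rings, which 2,5-dimethylpyrrolidin-1-yl lacks. Among the compounds with values here, the measured step touches the same place but a different exchange, so it is only a loose guide, and no measured pair shows what such a double bond does. A small step in this assay seems the most reasonable expectation, perhaps toward a somewhat higher number, and probably no larger than the measured one. The expected change is a 1.3-fold higher number from compound 2 to compound 3 (0.13 log units; within the scatter). Compound 3 is estimated at 13 mL.min-1.g-1, with an expected range of 6 mL.min-1.g-1 to 30 mL.min-1.g-1.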

Compound 3, intrinsic clearance in microsomes: 8.7 mL.min-1.g-1
For compound 3 the middle estimate is 1.5-fold (0.17 log units) above the measured one; measured number inside the range.
By their numbers in this assay, from the lowest: compounds 3 and 2 (each within the scatter of the next); then compound 1.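

In this assay, adding a double bond outside aromatic rings to the five-membered ring at this position, on an aromatic carbon, gives a 1.1-fold lower number from compound 2 to compound 3 (0.05 log units; within the scatter) and so leaves compound 2 and compound 3 indistinguishable on this read-out. The piperidin-1-yl group of compound 1 remains clearly apart from the new group, with a 4.0-fold lower number from compound 1 to compound 3 (0.60 log units; beyond the scatter) alongside the earlier 3.6-fold lower number from compound 1 to compound 2 (0.56 log units; beyond the scatter) as the other step of this kind, so both five-membered groups shown sit on the slower-clearance side of the six-membered one. Nothing measured here explains these numbers or says which part of either molecule the microsomes act on.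

The compounds shown leave open whether the lower numbers of compound 2 and compound 3 go with the five-membered ring itself or with its two methyl groups, a question that a plain pyrrolidin-1-yl group would address. From the compounds shown here alone, how a ring carrying an oxygen atom, such as morpholin-4-yl, would read at this position also remains open.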